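This account rests on a few compounds, and the source may have more. Where it says the series, first, only, none or still open, it means among the compounds named here.

In a functional assay on HCT-116 cells (Homo sapiens) for inhibition, read by MTT assay, with a stated time of 48 h (a lower number here means a stronger inhibitor, a higher number a weaker inhibitor), compound 1 (`CC/C=C/C(=O)N(Cc1ccc(OC)c(O)c1)c1cc(OC)c(OC)c(OC)c1`) gives 63 nM and compound 2 (`COc1ccc(CN(C(=O)CCl)c2cc(OC)c(OC)c(OC)c2)cc1O`) gives 250 nM as the higher of the two numbers, so compound 2 is the weaker inhibitor of this pair. Compound 3 (`COc1ccc(CN(C(=O)CCCl)c2cc(OC)c(OC)c(OC)c2)cc1O`) has not been measured yet. It differs from compound 2 in one place, with chloromethyl in place of chloro on a saturated chain carbon bound to a carbonyl carbon in the exchange: chloromethyl in place of chloro on a saturated chain carbon bound to a carbonyl carbon, which also reads as chloromethyl to 2-chloroethyl.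

Among the measured compounds shown here, no measured pair shows this exact change. For the measured compounds named here, the only measured step that bears on it is a 4.0-fold higher number from compound 1 to compound 2 (0.60 log units; beyond the scatter) when chloromethyl takes the place of but-1-en-1-yl on a carbonyl carbon. That modest step shows that the number can move when the group on this carbonyl carbon changes, but it does not show what this smaller exchange will do. The expected change is therefore slight, and the estimated step is a 1.3-fold lower number from compound 2 to compound 3 (0.10 log units; within the scatter) with no move beyond the scatter expected. For compound 3 the estimate is 200 nM with an expected range from 70 nM to 600 nM in this assay once it is measured.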

Compound 3, half-maximal inhibitory concentration: 150 nM
The estimate for compound 3 lay 1.3-fold (0.12 log units) above the measured number; the measured number falls inside the stated range.
By their numbers in this assay, from the lowest: compound 1; then compounds 3 and 2 (each within the scatter of the next).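

In this assay, the exchange of chloromethyl for 2-chloroethyl on the carbonyl carbon gives a 1.7-fold lower number from compound 2 to compound 3 (0.22 log units; within the scatter), so this position tolerates the exchange without a change that can be told apart from the scatter of repeated measurements. The difference from the but-1-en-1-yl group of compound 1 holds for both chlorine-bearing groups, with a 2.4-fold higher number from compound 1 to compound 3 (0.38 log units; beyond the scatter) standing beside the earlier 4.0-fold higher number from compound 1 to compound 2 (0.60 log units; beyond the scatter), and both of these modest steps lie beyond the scatter, which leaves compound 1 as the strongest inhibitor of the three. Nothing at hand explains why these numbers fall as they do.

The compounds shown leave open whether the chlorine itself matters at this position, which a plain ethyl or butyl group on the carbonyl carbon would help to answer, and whether the double bond of compound 1 matters. They also leave open how the number would respond to a longer chain such as 3-chloropropyl, or to an amine or a carboxylic acid at the end of the chain in place of the chlorine.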